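A change at the carbonyl where every value sits at a limit

The source may hold more compounds than are shown below. What is called first, only, known or untested is meant among the compounds shown, and "the series" means these compounds.

In a functional assay on SW-620 cells (Homo sapiens) for inhibition, read by sulforhodamine B assay, with a stated time of 48 h (a lower number here means that less compound is tolerated, a higher number that more compound is tolerated), compound 2 `COc1cc(-c2nn(-c3cccc(NC(=O)c4cccc(C(F)(F)F)c4)c3)cc2-c2ccncc2)ccc1Cl` gives > 50000 nM, which is a limit of the assay and not a number. Two companions on the shared core are also known only as limits. In this assay compound 1 `O=C(Nc1cccc(-n2cc(-c3ccncc3)c(-c3ccc(Cl)c(O)c3)n2)c1)Nc1cccc(C(F)(F)F)c1` gives > 32500 nM, a limit. In this assay compound 3 `O=C(Nc1cccc(-n2cc(-c3ccncc3)c(-c3ccc(Cl)c(O)c3)n2)c1)Nc1ccc(Cl)c(Cl)c1` gives > 32500 nM, again a limit. For the measured compounds named here, the one step between measured compounds, from compound 1 to compound 3, a step that the two limits leave unreadable from compound 1 to compound 3, is therefore unreadable. What the numbers show is summarised by the limit of > 32500 nM in this assay, at which 2 of the 3 values shown sit, and by the limit of > 50000 nM in this assay, at which 1 of the 3 values shown sits.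

Compound 4 `COc1cc(-c2nn(-c3cccc(NC(=O)Nc4cccc(C(F)(F)F)c4)c3)cc2-c2ccncc2)ccc1Cl` differs from compound 2 by (3-(trifluoromethyl)phenyl)amino in place of 3-(trifluoromethyl)phenyl on a carbonyl carbon. Going by the values given here, no measured step covers this change, and the single step that is known says nothing about its size or direction. With compound 2 itself at a limit and every neighbour at a limit, compound 4 is expected to remain at or near the limit too. The estimate for compound 4 is 50000 nM, with a range from 20000 nM to 120000 nM. This estimate means an expected step of a number no higher from compound 2 to compound 4 (the limit leaves the size open) that stays within the scatter.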

Compound 4, concentration lethal to 50% of the cells: 50000 nM
For compound 4 middle estimate and measured number coincide at the digits printed; low and high end bracket the measured number.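

In this assay, for the compounds shown here, compound 4 gives 50000 nM, the first value in this set that is a number and not a limit. On these data alone, putting (3-(trifluoromethyl)phenyl)amino in place of 3-(trifluoromethyl)phenyl on a carbonyl carbon gives a number no higher from compound 2 to compound 4 (the limit leaves the size open), so this position now has one readable end, though the size of the change stays unknown. The step that swaps hydrogen for methyl on an oxygen on an aromatic ring cannot be read, and limits still dominate the series: the limit of > 32500 nM in this assay, at which 2 of the 4 values shown sit.

As far as these compounds go, how far compound 2 really lies from compound 4 remains open, and so does the effect of the oxygen substituent on the core of compound 4. Also open, from the compounds shown here alone, is what a morpholine or a carboxylic acid on that carbonyl carbon would give in this assay.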